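Changing Fluoro to Chloro on a Weak Antiproliferative Compound

A few compounds are considered here, and "the series" means these few. Any claim that something is new, unique, unknown or untested is made for them only; others in the source may bear on it.

Within the data shown here, in a functional assay on B16-F10 cells (Mus musculus) for antiproliferative activity, read by MTT assay, with a stated time of 48 h (on this read-out lower numbers stand for stronger inhibition and higher numbers for weaker inhibition), compound 2 `Cc1ccc(-c2nn(-c3ccccc3)cc2CNc2ccc(F)cc2)cc1` gives 5670 nM, the highest of the two numbers so far, while compound 1 `Fc1ccc(NCc2cn(-c3ccccc3)nc2-c2ccc(Cl)cc2)cc1` gives 2120 nM. Compound 3 `Cc1ccc(-c2nn(-c3ccccc3)cc2CNc2ccc(Cl)cc2)cc1` has chloro in place of fluoro on an aromatic carbon of compound 2: chloro in place of fluoro on an aromatic carbon. Among the measured compounds shown here, no measured step makes this exact swap. The only one, a 2.7-fold higher number from compound 1 to compound 2 (0.43 log units; beyond the scatter), is a modest change of methyl in place of chloro elsewhere in the molecule, so it offers only indirect guidance, with the chloro compound giving the lower number. A modest move towards stronger inhibition is therefore expected, a 1.6-fold lower number from compound 2 to compound 3 (0.21 log units; within the scatter). For compound 3 the estimated value is 3500 nM, with an expected range of 1500 nM to 8000 nM.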

Compound 3, half-maximal inhibitory concentration: 6010 nM
Estimate against measurement, compound 3: 1.7-fold (0.23 log units) below; the measured number falls inside the stated range.
By their numbers in this assay, from the lowest: compound 1; then compounds 2 and 3 (each within the scatter of the next).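

In this assay, chloro in place of fluoro on this ring, para to a large group, gives a 1.1-fold higher number from compound 2 to compound 3 (0.03 log units; within the scatter), so the two halogens cannot be told apart at this position in this molecule. The earlier step, methyl in place of chloro, lay elsewhere in the molecule and went beyond the scatter, whereas this swap does not. Nothing available explains this result.

From the compounds shown here alone, whether a group other than a halogen, such as an amine or a carboxylic acid, would read the same here remains open. So does whether the fluoro-to-chloro swap would also sit within the scatter on the core of compound 1, which carries chloro where compound 2 carries methyl.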